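From a Thienyl to a Fluorophenyl Ring: Expected Tolerance

A few compounds are considered here, and "the series" means these few. Any claim that something is new, unique, unknown or untested is made for them only; others in the source may bear on it.

Three compounds sharing one core have been examined in a toxicity assay on Vero cells (Chlorocebus sabaeus) for cytotoxicity; a higher number here means that more compound is tolerated, a lower number that less compound is tolerated. Compound 1 `COc1nc(-c2ccccc2F)ccc1[C@@H](c1ccccc1)[C@@](O)(CCN(C)C)c1cccc2ccccc12` reaches only the limit of the assay there, giving > 50 ug/mL. Compound 2 `COc1nc(C2CCCCC2)ccc1[C@@H](c1ccccc1)[C@@](O)(CCN(C)C)c1cccc2ccccc12` gives 32.3 ug/mL, and compound 3 `COc1nc(-c2ccsc2)ccc1[C@@H](c1ccccc1)[C@@](O)(CCN(C)C)c1cccc2ccccc12` gives 24.4 ug/mL. Among the two actual numbers compound 3 has the lower one, but the gap between them is a 1.3-fold lower number from compound 2 to compound 3 (0.12 log units; within the scatter), so the two cannot be ordered. From compound 1 the recorded changes were an at least 1.5-fold lower number from compound 1 to compound 2 (0.18 log units; that floor lies within the scatter) and an at least 2.0-fold lower number from compound 1 to compound 3 (0.31 log units; beyond the scatter); both rest on the fact that (the limit of > 50 ug/mL in this assay, at which 1 of the 3 values shown sits).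

Compound 4 `COc1nc(-c2ccc(F)cc2)ccc1[C@@H](c1ccccc1)[C@@](O)(CCN(C)C)c1cccc2ccccc12` has not yet been measured. It differs from compound 3 in one place: 4-fluorophenyl in place of thiophen-3-yl on an aromatic carbon. The step that bears most on this change is the one in which an at least 2.0-fold lower number from compound 1 to compound 3 (0.31 log units; beyond the scatter), since compound 4 returns to a fluorophenyl ring of the kind compound 1 carries. An upward movement in this assay is expected for compound 4 because compound 1 gives > 50 ug/mL with its own fluorophenyl group. The expected size is a 1.8-fold higher number from compound 3 to compound 4 (0.27 log units; within the scatter). Compound 4 is therefore estimated at 45 ug/mL, with a range from 25 ug/mL to 80 ug/mL.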

Compound 4, half-maximal cytotoxic concentration: > 50 ug/mL
Compound 4 ended at the assay's limit; the forecaster's own chance of this, stated with the estimate: 45%; middle value at least 1.1-fold (0.04 log units) from the limit.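

With an at least 2.0-fold higher number from compound 3 to compound 4 (0.31 log units; beyond the scatter) in this assay, the 4-fluorophenyl group joins the 2-fluorophenyl group of compound 1 in a step from thiophen-3-yl that lies beyond the scatter, so this result at the position next to the ring nitrogen no longer rests on a single fluorophenyl compound. The comparison with cyclohexyl is less firm, at an at least 1.5-fold higher number from compound 2 to compound 4 (0.18 log units; that floor lies within the scatter), and it leaves compound 2 and compound 4 unordered. The step between compound 1 and compound 4 cannot be read, and the two readable steps give only floors, not full sizes: the limit of > 50 ug/mL in this assay, at which 2 of the 4 values shown sit.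

On these data alone, how far compound 1 and compound 4 would lie from each other without the limit remains open, so nothing can be said about whether moving the fluorine around the phenyl ring matters in this assay. Also open, as far as these compounds go, is whether the fluorine is needed at all, and how an unsubstituted phenyl ring, or a phenyl ring carrying an amine or a carboxylic acid, would compare with thiophen-3-yl at this position.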